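Substituent changes on the aromatic nitrogen: compounds 1 to 4

This account rests on a few compounds, and the source may have more. Where it says the series, first, only, none or still open, it means among the compounds named here.

Compound 1 `CCn1c(-c2ccc(OCc3c(-c4c(Cl)cccc4Cl)noc3C(C)C)cc2)nc2ccc(C(=O)O)cc21` gives 2.31 nM in an assay on Huh-7 cells for agonist activity at Bile acid receptor (Homo sapiens), read by a luciferase reporter; a lower number here means that less compound is needed, a higher number that more compound is needed for the effect.
Compound 2 `CCCC(CCC)n1c(-c2ccc(OCc3c(-c4c(Cl)cccc4Cl)noc3C(C)C)cc2)nc2ccc(C(=O)O)cc21` gives 1.8 nM in this assay.
Compound 3 `CC(C)Cn1c(-c2ccc(OCc3c(-c4c(Cl)cccc4Cl)noc3C(C)C)cc2)nc2ccc(C(=O)O)cc21` gives 5.26 nM in this assay.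

Compound 3 has the highest number of the three: a 2.3-fold higher number from compound 1 to compound 3 (0.36 log units; beyond the scatter) and a 2.9-fold higher number from compound 2 to compound 3 (0.47 log units; beyond the scatter), while a 1.3-fold lower number from compound 1 to compound 2 (0.11 log units; within the scatter). Compound 4 `CC(C)c1onc(-c2c(Cl)cccc2Cl)c1COc1ccc(-c2nc3ccc(C(=O)O)cc3n2C2CCCC2)cc1` carries cyclopentyl in place of isobutyl on an aromatic nitrogen. Both measured steps that leave compound 3 lower the number, with the branched 1-propylbutyl of compound 2 giving the lowest value seen, so the cyclopentyl, also branched at the carbon bound to the ring nitrogen, is expected to move in the same direction. The estimate for compound 4 is therefore a 2.1-fold lower number from compound 3 to compound 4 (0.32 log units; beyond the scatter), landing at 2.5 nM with a range of 1 nM to 6 nM.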

Compound 4, half-maximal effective concentration: 13.6 nM
Compound 4: the middle estimate sits 5.4-fold (0.74 log units) below what was measured; the measured number lies above the stated range.
By their numbers in this assay, from the lowest: compounds 2 and 1 (each within the scatter of the next); then compound 3; then compound 4.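

Branching at the carbon bound to the aromatic nitrogen does not by itself keep the number low in this assay: cyclopentyl gives a 2.6-fold higher number from compound 3 to compound 4 (0.41 log units; beyond the scatter) and also a 7.6-fold higher number from compound 2 to compound 4 (0.88 log units; beyond the scatter) even though 1-propylbutyl is branched at that carbon too. Even the small ethyl compares favourably, with a 5.9-fold higher number from compound 1 to compound 4 (0.77 log units; beyond the scatter) as the step to the cyclopentyl. Nothing measured here accounts for this difference.

Going by these compounds, whether the ring itself or its size drives the higher number stays open. Cyclopropyl, cyclohexyl or isopropyl on the same aromatic nitrogen would help separate these.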